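Trading two methoxy groups for a trifluoromethyl on the benzyl arm

The source may hold more compounds than are shown below. What is called first, only, known or untested is meant among the compounds shown, and "the series" means these compounds.

Two sulfonamides share a bis(trifluoromethyl)phenyl sulfonyl head and a benzylamine tail. In a functional assay on MCF7 cells (Homo sapiens) for inhibition, read by MTT assay, with a stated time of 72 h (a higher number here means a weaker inhibitor of growth, a lower number a stronger inhibitor of growth), compound 1 `O=S(=O)(NCCNCc1ccc(-c2ccccc2)cc1)c1cc(C(F)(F)F)cc(C(F)(F)F)c1` gives 1400 nM, while compound 2 `COc1ccc(CNCCCNS(=O)(=O)c2cc(C(F)(F)F)cc(C(F)(F)F)c2)cc1OC` gives 1900 nM. Compound 2 stands with the higher of the two numbers, but its gap to compound 1 is within the scatter, so the two compounds cannot be ordered on these data. Compound 3 `O=S(=O)(NCCCNCc1ccc(C(F)(F)F)cc1)c1cc(C(F)(F)F)cc(C(F)(F)F)c1`, not yet measured, carries 4-(trifluoromethyl)phenyl in place of 3,4-dimethoxyphenyl on a saturated chain carbon bound to an amine nitrogen. Among the compounds with values here, no measured pair isolates this change, so the step can only be an expectation. Since the values of compound 1 and compound 2 sit within the scatter despite differing in both chain and aryl group, compound 3 is expected to stay near this same range, and the estimated step of a 1.3-fold lower number from compound 2 to compound 3 (0.10 log units; within the scatter) is expected to fall within the scatter. For compound 3 in this assay the estimate is 1500 nM, with a range from 600 nM to 3800 nM.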

Compound 3, concentration for 50% growth inhibition: 1400 nM
Beside the measured number, compound 3's estimate is 1.1-fold (0.03 log units) above it; the range from low to high includes it.
By their numbers in this assay, from the lowest: compounds 1, 3 and 2 (each within the scatter of the next).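

In this assay, within the data shown here, compound 2 and compound 3 form the first pair that differs in one place, and they give a 1.4-fold lower number from compound 2 to compound 3 (0.13 log units; within the scatter). At this position, on a saturated chain carbon bound to an amine nitrogen, 4-(trifluoromethyl)phenyl can therefore stand in for 3,4-dimethoxyphenyl without a readable difference, even though the entering group has 0 hydrogen-bond acceptors and the leaving group has 2. The data offer no measurement that would account for this result.

From the compounds shown here alone, whether a benzyl arm carrying a nitrile or a carboxylic acid would stay in the same range remains open. The role of the chain is also open, since compound 1 differs from compound 2 and compound 3 in more than one place, and a longer chain does not appear among these compounds.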